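A few compounds are considered here, and "the series" means these few. Any claim that something is new, unique, unknown or untested is made for them only; others in the source may bear on it.

Measured compounds:
Compound 1, `COc1ccc(NC(=O)c2ccc3ccccc3n2)cc1` — 7650 nM
Compound 2, `O=C(Nc1ccccc1O)C1CCc2ccccc2N1` — 2230 nM

In a functional assay on NCI-H23 cells (Homo sapiens) for cytotoxicity, read by sulforhodamine B assay, with a stated time of 72 h (a higher number here means a weaker inhibitor of growth, a lower number a stronger inhibitor of growth), compound 1 gives 7650 nM, the higher of the two numbers recorded. Compound 2 gives 2230 nM, a lower number, and the gap between the two lies beyond the usual scatter of this assay. The two compounds differ in more than one place, so the gap cannot be assigned to any single change.

Compound 3, `O=C(Nc1ccc(O)cc1)c1ccc2ccccc2n1`, has not yet been measured in this assay. It is related to compound 1 by a single change: hydrogen in place of methyl on an oxygen on an aromatic ring. Among the measured compounds shown here, no pair of measured compounds shows this change in isolation, so there is no step on record to lean on. Compound 2 does carry a hydroxy on its anilide ring, but its core differs as well, so its value says nothing clean about the change itself.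

The expected step is a 1.5-fold lower number from compound 1 to compound 3 (0.18 log units; within the scatter), a small one, most likely toward a somewhat lower number and not clearly beyond the scatter. Compound 3 is estimated at 5000 nM, with a range from 1500 nM to 15000 nM.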

Compound 3, concentration for 50% growth inhibition: 102000 nM
The estimate for compound 3 lay 20-fold (1.31 log units) below the measured number, and the stated range ends below it.
By their numbers in this assay, from the lowest: compound 2; then compound 1; then compound 3.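

In this assay, among the compounds shown here, the pair compound 1 and compound 3 gives the first clean reading of this position, with a 13-fold higher number from compound 1 to compound 3 (1.12 log units; beyond the scatter) on replacing methoxy by hydroxy. For the compounds shown here, the loss of a single methyl from an oxygen on an aromatic ring is therefore far from a neutral change on this core, and the methyl counts for much more in growth inhibition than the earlier compounds could show. No measurement on hand bears on what lies behind a step of this size, so the result stands as an observation only.

Only methoxy and hydroxy are shown in this place, so it remains open whether the step follows the loss of the methyl itself or the presence of the free hydroxy, and an ethoxy group, an amine or a fluorine there would help to separate the two. On these data alone, this change also rests on one pair, so whether a step of this size would recur on another core, such as that of compound 2, remains open.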